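Demethylation of the methoxyphenyl side chain in compound 3

A few compounds are considered here, and "the series" means these few. Any claim that something is new, unique, unknown or untested is made for them only; others in the source may bear on it.

The series shares one core, seen in compound 1 `CCc1nc(N)c2nn(-c3ccccc3)cc2n1`, which in an assay on CHO cells for displacement of a labelled ligand from adenosine receptor A1 (Homo sapiens), read by scintillation counting (a lower number here means a stronger inhibitor, a higher number a weaker inhibitor), gives 90 nM. Compound 2 `Nc1nc(Cc2cccc(O)c2)nc2cn(-c3ccccc3)nc12` gives 312 nM in this assay, and compound 3 `COc1ccc(CCc2nc(N)c3nn(-c4ccccc4)cc3n2)cc1` gives 380 nM. Compound 3 carries the highest number of the three: the gap to compound 2 is within the scatter, the gap to compound 1 beyond it. Both steps away from compound 1 are modest: a 3.5-fold higher number from compound 1 to compound 2 (0.54 log units; beyond the scatter) and a 4.2-fold higher number from compound 1 to compound 3 (0.63 log units; beyond the scatter).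

Compound 4 `Nc1nc(CCc2ccc(O)cc2)nc2cn(-c3ccccc3)nc12` differs from compound 3 by hydrogen in place of methyl on an oxygen on an aromatic ring. Going by the values given here, no measured pair removes a methyl from an oxygen on an aromatic ring, so there is no direct guide. The closest hint is that compound 2, whose aryl carries a hydroxy group, and compound 3, whose aryl carries a methoxy group, give numbers within the scatter of each other. The step is therefore expected to be a 1.2-fold lower number from compound 3 to compound 4 (0.07 log units; within the scatter), not beyond the scatter. Compound 4 is estimated at 320 nM in this assay, with a range from 130 nM to 800 nM.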

Compound 4, inhibition constant: 420 nM
Compound 4: the middle estimate sits 1.3-fold (0.12 log units) below what was measured, within the range that was stated.
By their numbers in this assay, from the lowest: compound 1; then compounds 2, 3 and 4 (each within the scatter of the next).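

Taking the methyl off the oxygen on the aromatic ring gives a 1.1-fold higher number from compound 3 to compound 4 (0.04 log units; within the scatter) in this assay and is the first direct pair showing that this change does not separate 4-methoxyphenyl from 4-hydroxyphenyl on this chain. The gap to compound 1 remains with the hydroxy group in place, at a 4.7-fold higher number from compound 1 to compound 4 (0.67 log units; beyond the scatter) and so the methyl on the oxygen is not needed for that gap in this pair, while a 1.3-fold higher number from compound 2 to compound 4 (0.13 log units; within the scatter) shows the two hydroxy-bearing side chains without separation. Nothing available explains why the methyl can go without a readable change.

Still open, on these data alone, is whether an amine or a carboxylic acid in place of the hydroxy group would also leave the number unchanged. A longer chain carrying the 4-hydroxyphenyl group is equally untested by the compounds shown.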